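The compounds below may be only part of what the source reports. "The series", "measured", "known", "first", "only" and "open" are said of these compounds alone.

Compound 1 `CN1CCC(Oc2ccc(Nc3ncc4nc([S+]([O-])c5ccccc5)n(C5CCOCC5)c4n3)cc2)CC1`, compound 2 `CN1CCN(c2ccc(Nc3ncc4nc([S+]([O-])Cc5cccnc5)n(C5CCOCC5)c4n3)cc2)CC1` and compound 3 `CN1CCN(c2ccc(Nc3ncc4nc([S+]([O-])Cc5cccnc5)n(C5CCCC5)c4n3)cc2)CC1` are the three compounds with numbers, and compound 4 `CN1CCN(c2ccc(Nc3ncc4nc(SCc5cccnc5)n(C5CCOCC5)c4n3)cc2)CC1` is the one still to be tested.

In a functional assay on HCC827 cells (Homo sapiens) for antiproliferative activity, read by MTT assay, with a stated time of 72 h (on this read-out higher numbers stand for weaker inhibition and lower numbers for stronger inhibition), compound 1 gives 853 nM. Compound 3 gives 2350 nM in the same test. For compound 2 the assay reports only a limit, > 10000 nM. That limit is the limit of > 10000 nM in this assay, at which 1 of the 3 values shown sits. Among the measured compounds shown here, compound 2 therefore stands at the weak end of the three, without a number of its own, and the single measured step that touches it, an at least 4.2-fold lower number from compound 2 to compound 3 (0.62 log units; beyond the scatter), arises from cyclopentyl in place of oxan-4-yl on an aromatic nitrogen.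

Compound 4 differs from compound 2 in a different place: a group of 8 heavy atoms (6 carbon, 1 nitrogen, 1 sulfur; one six-membered aromatic ring with 1 hetero atom) in place of a group of 9 heavy atoms (6 carbon, 1 nitrogen, 1 oxygen, 1 sulfur; one six-membered aromatic ring with 1 hetero atom), on an aromatic carbon. For the measured compounds named here, no measured step involves this exchange of the sulfinyl for the sulfanyl linker, so the step from compound 2 to compound 3 does not speak to it directly, and the expectation for compound 4 rests on the position of compound 2 at the limit alone. Compound 4 is expected to land near 7000 nM, with a range from 2000 nM to 20000 nM, which would mean an estimated step of an at least 1.4-fold lower number from compound 2 to compound 4 (0.15 log units; that floor lies within the scatter), and with a real chance that only a limit is reported again.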

Compound 4, half-maximal inhibitory concentration: 500 nM
The estimate for compound 4 lay 14-fold (1.15 log units) above the measured number; the measured number lies below the stated range.
By their numbers in this assay, from the lowest: compounds 4 and 1 (each within the scatter of the next); then compound 3. At a limit, above all of these: compound 2.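

In this assay, among the compounds shown here, replacing the sulfinyl linker with ((pyridin-3-yl)methyl)sulfanyl on the aromatic carbon between two ring nitrogen atoms gives an at least 20-fold lower number from compound 2 to compound 4 (1.30 log units; beyond the scatter), and this is the first measured change at this position. For the compounds shown here, the only earlier step, an at least 4.2-fold lower number from compound 2 to compound 3 (0.62 log units; beyond the scatter), concerned the group on the aromatic nitrogen, whereas compound 2 and compound 4 both keep oxan-4-yl there, which shows that the change at the aromatic carbon alone can move the read-out well beyond the scatter. From the compounds shown here alone, the true size of the new step remains unknown, as compound 2 is reported only as a limit, so the step gives a floor and not a measured distance: the limit of > 10000 nM in this assay, at which 1 of the 4 values shown sits.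

The compounds shown leave open whether cyclopentyl on the aromatic nitrogen would lower the number further when paired with the sulfanyl linker of compound 4, since the step to cyclopentyl is known only with the sulfinyl linker. They also leave open how a sulfonyl group, an ether oxygen or an amine in place of the sulfur at this position would compare, and whether the pyridin-3-yl ring is needed for the result seen with compound 4.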